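Replacing the Amine Amide with a Fluorobenzyl Ester

The compounds below may be only part of what the source reports. "The series", "measured", "known", "first", "only" and "open" are said of these compounds alone.

Compound 1 `CCn1c(C(=O)NCCN)ccc1C(CC)(CC)c1ccc(OCC(=O)C(C)(C)C)c(C)c1` gives 120 nM in an assay on HL-60 cells for agonist activity at vitamin D3 receptor (Homo sapiens), read by microscopy, with a stated time of 96 h (on this read-out lower numbers stand for an effect already at smaller amounts and higher numbers for an effect only at larger amounts of compound), the higher of the two numbers obtained there. Compound 2 `CCn1c(C(=O)NCCN)ccc1C(CC)(CC)c1ccc(OCC(O)C(C)(C)C)c(C)c1` gives 10 nM, so that there is a 12-fold lower number from compound 1 to compound 2 (1.08 log units; beyond the scatter). Compound 3 `CCOC(=O)c1ccc(OC(=O)c2ccc(C(CC)(CC)c3ccc(OCC(O)C(C)(C)C)c(C)c3)n2CC)cc1` gives > 50000 nM, which is a limit of this assay and not a number. This amounts to an at least 5000-fold higher number from compound 2 to compound 3 (3.69 log units; beyond the scatter). Compound 4 `CCn1c(C(=O)OCc2ccc(F)cc2)ccc1C(CC)(CC)c1ccc(OCC(=O)C(C)(C)C)c(C)c1` has not yet been measured; it differs from compound 1 by (4-fluorobenzyl)oxy in place of (2-aminoethyl)amino on a carbonyl carbon. The step from compound 2 to compound 3 bears on this change, as it also replaced the (2-aminoethyl)amino on the carbonyl carbon with an ester, and it was large. A large rise is therefore expected, an 83-fold higher number from compound 1 to compound 4 (1.92 log units; beyond the scatter). The estimate for compound 4 is 10000 nM, expected between 1000 nM and 50000 nM.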

Compound 4, half-maximal effective concentration: 9500 nM
Compound 4: the middle estimate sits 1.1-fold (0.02 log units) above what was measured; measured number inside the range.
By their numbers in this assay, from the lowest: compound 2; then compound 1; then compound 4. At a limit, above all of these: compound 3.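

In this assay, (4-fluorobenzyl)oxy in place of (2-aminoethyl)amino on the carbonyl carbon gives a 79-fold higher number from compound 1 to compound 4 (1.90 log units; beyond the scatter). An ester here thus goes with a large rise on the (tert-butyl)carbonyl side chain too, not only on the hydroxylated one, and this step has a number at both ends. The earlier ester, compound 3, gives only a limit of the assay: the limit of > 50000 nM in this assay, at which 1 of the 4 values shown sits.

On these data alone, whether the rise goes with losing the amine of the (2-aminoethyl)amino group or with the ester oxygen stays open. A benzylamide or a carboxylic acid on this carbonyl carbon would separate the two.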